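Benzyl in Place of Cyclohexyl on the Shared Core

The source may report more compounds than this note shows. Statements on the series, on what has been measured and on what is new or still open speak of the compounds shown alone.

Compound 1 `c1ccc(-c2cn3ccnc3c(-c3ccc4ncn(C5CCCCC5)c4c3)n2)cc1`: 16.5%
Compound 2 `c1ccc2c(-c3cn4ccnc4c(-c4ccc5ncn(C6CCCCC6)c5c4)n3)cccc2c1`: 2.3%
Compound 3 `Fc1ccccc1-c1cn2ccnc2c(-c2ccc3ncn(C4CCCCC4)c3c2)n1`: 10.5%

In a functional assay on SK-MEL-2 cells (Homo sapiens) for inhibition, read by sulforhodamine B assay, with a stated time of 48 h, tested at 10 uM (a higher number here means more inhibition at the concentration tested (going by the name of the read-out), a lower number less inhibition), compound 2 stands lowest of the three numbers: the step of a number 8.2 percentage points higher from compound 2 to compound 3 (within the scatter) stays within the scatter, while the step of a number 14.2 percentage points lower from compound 1 to compound 2 (beyond the scatter) lies beyond it. Compound 4 `c1ccc(Cn2cnc3ccc(-c4nc(-c5cccc6ccccc56)cn5ccnc45)cc32)cc1` differs from compound 2 in one place: benzyl in place of cyclohexyl on an aromatic nitrogen. Among the measured compounds shown here, both measured steps, a number 14.2 percentage points lower from compound 1 to compound 2 (beyond the scatter) and a number 6 percentage points lower from compound 1 to compound 3 (within the scatter), change only the group on an aromatic carbon; none of them alters the group on the ring nitrogen, so no measured step bears directly on this change. With nothing to point either way, the step of a number 5.7 percentage points higher from compound 2 to compound 4 (within the scatter) is expected to stay within the scatter. For compound 4 the inhibition is therefore estimated at 8%, within a range from 0% to 25%.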

Compound 4, a percentage reported as inhibition, at one concentration (the size of the read-out at that concentration, not a potency): 17%
Compound 4: middle estimate off by 9 percentage points, on the low side; the measured number falls inside the stated range.
By their numbers in this assay, from the lowest: compounds 2, 3, 1 and 4 (each within the scatter of the next, the first and the last beyond it).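

In this assay, among the compounds shown here, the group on the aromatic nitrogen now has a measured step of its own: benzyl in place of cyclohexyl gives a number 14.7 percentage points higher from compound 2 to compound 4 (beyond the scatter) and this is the first change at that position. The earlier steps changed only the group on an aromatic carbon, so the ring nitrogen is now shown to be a place where a change can move the number, at least with naphthalen-1-yl on the shared core. No evidence is available to explain this step.

As far as these compounds go, whether benzyl does the same with phenyl or 2-fluorophenyl on the core remains open. So does how an open alkyl chain or a benzyl carrying a carboxylic acid would read on that nitrogen.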